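Notes on a dimethylphenyl variation in the sulfonamide series

The source may hold more compounds than are shown below. What is called first, only, known or untested is meant among the compounds shown, and "the series" means these compounds.

Of the compounds shown here, three have been measured in an ADME assay on C8166 cells (Homo sapiens) for cytotoxicity, read by colorimetric assay and MTT assay; on this read-out higher numbers stand for lower toxicity in this test and lower numbers for higher toxicity in this test. Compound 1 `Cc1cc(S(N)(=O)=O)ccc1NC(=O)COc1ccc2ccccc2c1C(=O)c1ccccc1` gives 33800 nM. Compound 2 `Cc1ccc(C(=O)c2c(OCC(=O)Nc3ccc(S(N)(=O)=O)cc3C)ccc3ccccc23)c(C)c1` gives 25500 nM, and compound 3 `Cc1cc(S(N)(=O)=O)ccc1NC(=O)COc1ccc2cc(Br)ccc2c1C(=O)c1ccccc1` gives 29200 nM. Compound 3 stands second highest of the three numbers, nearest to compound 2 and furthest from compound 1, but both gaps lie within the scatter, so no order among the three is claimed. Two steps differ in one place: a 1.3-fold lower number from compound 1 to compound 2 (0.12 log units; within the scatter) and a 1.2-fold lower number from compound 1 to compound 3 (0.06 log units; within the scatter).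

Compound 4 `Cc1ccc(C)c(C(=O)c2c(OCC(=O)Nc3ccc(S(N)(=O)=O)cc3C)ccc3cc(Br)ccc23)c1` has not been measured. It differs from compound 3 in that (2,5-dimethylphenyl in place of phenyl on a carbonyl carbon). Among the compounds with values here, the step that bears on this is the one from compound 1 to compound 2, where 2,4-dimethylphenyl replaced phenyl on the carbonyl carbon and the number moved within the scatter. The bromo in place of hydrogen on an aromatic carbon, shared by compound 3 and compound 4, likewise left the number within scatter in the step from compound 1 to compound 3. For compound 4 the expected step is therefore a 1.2-fold lower number from compound 3 to compound 4 (0.07 log units; within the scatter), nothing beyond the scatter. Compound 4 is estimated at 25000 nM, with a range from 12000 nM to 50000 nM.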

Compound 4, half-maximal cytotoxic concentration: 14000 nM
Compound 4: the middle estimate sits 1.8-fold (0.25 log units) above what was measured, within the range that was stated.
By their numbers in this assay, from the lowest: compounds 4, 2, 3 and 1 (each within the scatter of the next, the first and the last beyond it).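

In this assay, the position on the carbonyl carbon now shows a change beyond the scatter: 2,5-dimethylphenyl in place of phenyl gives a 2.1-fold lower number from compound 3 to compound 4 (0.32 log units; beyond the scatter), a modest move towards higher toxicity in this test. The earlier replacement by 2,4-dimethylphenyl, made without the bromo, gave a 1.3-fold lower number from compound 1 to compound 2 (0.12 log units; within the scatter), so this position cannot be treated as silent on the strength of that step alone, although the two steps differ both in the dimethylphenyl group and in the presence of the bromo. Nothing available explains the larger step.

On these data alone, it remains open whether the move belongs to 2,5-dimethylphenyl itself or appears only together with the bromo. Also open, as far as these compounds go, is how an aryl group carrying an amine or a carboxylic acid would behave on the same carbonyl carbon.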